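This account rests on a few compounds, and the source may have more. Where it says the series, first, only, none or still open, it means among the compounds named here.

Working notes, in an ADME assay on the whole organism (Mus musculus, strain CD-1) for metabolic stability, read by LC-MS, with a stated time of 4 h, at a dose of 10 mg/kg by the intraperitoneal route; a higher number here means that the compound lasts longer, a lower number that the compound disappears faster: compound 2 `CC(Sc1nc2nn(C3COC3)cc2c(=O)n1-c1ccccc1)c1ccccc1` gives 2.1 h as its half-life, the higher of the two numbers so far, and compound 1 `CC(Sc1nc2nn(C3COC3)cc2c(=O)n1-c1ccccc1)c1ccccn1` gives 0.6 h as its half-life. The next change leads to compound 3 `CC(Sc1nc2nn(C3(C)COC3)cc2c(=O)n1-c1ccccc1)c1ccccc1`: methyl in place of hydrogen on a saturated ring carbon turns oxetan-3-yl into 3-methyloxetan-3-yl, with methyl in place of hydrogen on a saturated ring carbon. Among the measured compounds shown here, only one measured step exists, a 3.5-fold higher number from compound 1 to compound 2 (0.54 log units; beyond the scatter) in this assay, and it is modest. It comes from phenyl in place of pyridin-2-yl, a different place in the molecule, so it bears only indirectly. It shows that a single group change can move this read-out beyond the scatter, but it gives no direction for the new change. For the measured compounds named here, no measured compound varies the oxetan-3-yl group. A small step within the scatter is therefore expected, leaning slightly upward without firm support. The estimated step is a 1.2-fold higher number from compound 2 to compound 3 (0.08 log units; within the scatter) in this assay on this thin basis. For compound 3 the expected half-life is 2.5 h with an estimated range from 1.2 h to 5 h in these notes.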

Compound 3, half-life: 1.6 h
Compound 3: the middle estimate sits 1.6-fold (0.19 log units) above what was measured; low and high end bracket the measured number.
By their numbers in this assay, from the lowest: compound 1; then compounds 3 and 2 (each within the scatter of the next).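

In this assay, among the compounds shown here, this is the first variation of the oxetan-3-yl group: methyl in place of hydrogen on a saturated ring carbon, turning it into 3-methyloxetan-3-yl, gives a 1.3-fold lower number from compound 2 to compound 3 (0.12 log units; within the scatter). In the presence of phenyl, therefore, this ring carbon tolerates the added methyl without a change in half-life that can be distinguished from the scatter, whereas phenyl in place of pyridin-2-yl gives a 3.5-fold higher number from compound 1 to compound 2 (0.54 log units; beyond the scatter), which is beyond the scatter and remains the only such step in the compounds shown. Nothing at hand explains the result for this methyl group.

Open is whether the methyl step would read the same way with pyridin-2-yl in place of phenyl, since the compounds shown pair hydrogen and methyl at this carbon only in the phenyl setting. Also open, going by these compounds, is how the half-life would respond to other groups on the same saturated ring carbon, such as an amine, a carboxylic acid or a longer chain, and so whether the read-out stays within the scatter only for methyl or also for groups beyond it.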